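The source may hold more compounds than are shown below. What is called first, only, known or untested is meant among the compounds shown, and "the series" means these compounds.

Measured compounds:

- compound 1, `O=C(Nc1cccc(C(F)(F)F)c1)c1c(NO)cc(-c2ccccc2)oc1=O`, gives 19000 nM in an ADME assay on Huh-7 cells (Homo sapiens) for cytotoxicity, with a stated time of 3 days; a lower number here means that less compound is tolerated, a higher number that more compound is tolerated.
- compound 2, `Cc1cccc(NC(=O)c2c(NO)cc(-c3cccs3)oc2=O)c1`, reaches only the limit of > 20000 nM in this assay.
- compound 3, `O=C(Nc1ccccc1)c1c(NCCO)cc(-c2cccc(Br)c2)oc1=O`, likewise gives only a limit, > 20000 nM, in this assay.

Compound 3 therefore stands at a limit rather than at a number, and one further value among those shown is a limit as well; what is known about this ceiling is the limit of > 20000 nM in this assay, at which 2 of the 3 values shown sit. Compound 4, `CCOc1ccccc1NC(=O)c1c(NCCO)cc(-c2cccc(Br)c2)oc1=O`, differs from compound 3 in one place: ethoxy in place of hydrogen on an aromatic carbon. For the measured compounds named here, no step between two measured compounds that differ in a single place is available, so the size of this step cannot be read from the measured set. Given that compound 3 sits at the limit > 20000 nM, the step from compound 3 to compound 4 in this assay is expected to be none beyond the scatter, a number no higher from compound 3 to compound 4 (the limit leaves the size open). Compound 4 is accordingly estimated at 20000 nM, with an expected range from 8000 nM to 50000 nM, and it may well return only a limit again.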

Compound 4, half-maximal cytotoxic concentration: > 20000 nM
Compound 4 was reported as a limit (the forecaster's own chance of this, stated with the estimate: 60%); the middle value lies on the limit itself.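

Compound 3 and compound 4 both stand only at a limit in this assay, so the size of the step between them cannot be read: the limit of > 20000 nM in this assay, at which 3 of the 4 values shown sit.

The compounds shown leave open whether ethoxy in place of hydrogen on an aromatic carbon changes the tolerated concentration at all.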